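The source may hold more compounds than are shown below. What is called first, only, known or untested is meant among the compounds shown, and "the series" means these compounds.

Measured compounds:
compound 1, `CCCCNc1nc(N)nc2ccc(F)cc12`: 0.1 uM
compound 2, `CCCCNc1nc(N)nc2ccc(C(C)O)cc12`: 5.8 uM
compound 3, `CCCCNc1nc(N)nc2cc(F)c(F)cc12`: not yet measured

In an ADME assay on HEK293 cells for agonist activity at Toll-like receptor 8 (Homo sapiens), read by a luciferase reporter, with a stated time of 6 h (on this read-out lower numbers stand for an effect already at smaller amounts and higher numbers for an effect only at larger amounts of compound), compound 1 gives 0.1 uM, the lower of the two numbers shown. For the measured compounds named here, its nearest neighbour is compound 2, which gives 5.8 uM; the step between them, a 58-fold higher number from compound 1 to compound 2 (1.76 log units; beyond the scatter), is the only measured step in this set. Compound 3 differs from compound 1 in one place: fluoro in place of hydrogen on an aromatic carbon. The measured step does not bear directly on this change, since it exchanged the fluoro group itself for a 1-hydroxyethyl group rather than adding a second fluoro beside a retained one. Going by the values given here, with no step of the same kind available, the expectation for compound 3 rests on the small size of the entering group, and the step of a 1.5-fold higher number from compound 1 to compound 3 (0.18 log units; within the scatter) is expected to stay within the scatter. Compound 3 is therefore estimated at 0.15 uM, between 0.05 uM and 0.5 uM.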

Compound 3, minimum effective concentration: 0.1 uM
For compound 3 the middle estimate is 1.5-fold (0.18 log units) above the measured one, within the range that was stated.
By their numbers in this assay, from the lowest: compounds 1 and 3 (each within the scatter of the next); then compound 2.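

In this assay, a fluoro group entering on the aromatic carbon ortho to a fluoro group gives no change at the digits printed from compound 1 to compound 3 (within the scatter), so this position takes that single added atom with no change beyond the scatter. The earlier step, a 58-fold higher number from compound 1 to compound 2 (1.76 log units; beyond the scatter), showed only that replacing the existing fluoro group with 1-hydroxyethyl carries a large change, and it said nothing about this neighbouring carbon, which now has its first reading. No available evidence accounts for either result.

The compounds shown leave open whether this carbon would accept anything larger than fluoro, such as a methoxy group, an amine or 1-hydroxyethyl, without a step beyond the scatter. They also leave open whether the new fluoro group would give the same result on a core lacking the original fluoro group.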